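Second chlorine on the benzylidene aryl: compound 3 to compound 4

A few compounds are considered here, and "the series" means these few. Any claim that something is new, unique, unknown or untested is made for them only; others in the source may bear on it.

Measured so far in a functional assay on HeLa cells (Homo sapiens) for cytotoxicity, read by CCK-8 assay, with a stated time of 72 h; a higher number here means a weaker inhibitor, a lower number a stronger inhibitor:
compound 1 `C=CCn1c(=O)/c(=C\c2cccc(Cl)c2)[nH]c(=O)/c1=C\c1ccccc1OC` gives 5500 nM;
compound 2 `COc1ccccc1/C=c1/[nH]c(=O)/c(=C\c2ccccc2OC)n(C)c1=O` gives "not active" (no number reported);
compound 3 `C=CCn1c(=O)/c(=C\c2ccccc2Cl)[nH]c(=O)/c1=C\c1ccccc1OC` gives 5100 nM.

Compound 3 lies together with compound 1 on these numbers; the step of a 1.1-fold lower number from compound 1 to compound 3 (0.03 log units; within the scatter) is within the scatter, so the two cannot be ordered. Compound 2 has no number in this assay.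

Compound 4 `C=CCn1c(=O)/c(=C\c2ccc(Cl)c(Cl)c2)[nH]c(=O)/c1=C\c1ccccc1OC` differs from compound 3 by 3,4-dichlorophenyl in place of 2-chlorophenyl on a double-bonded chain carbon bound to an aromatic carbon. Within the data shown here, the only step that bears on this place is the one from compound 1 to compound 3, which was within the scatter; no measured step adds a second chlorine to this aryl. The expectation is therefore no change beyond the scatter, a 1.1-fold lower number from compound 3 to compound 4 (0.05 log units; within the scatter), giving for compound 4 an estimated 4500 nM with a range of 1500 nM to 14000 nM.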

Compound 4, half-maximal inhibitory concentration: "not active" (no number reported)
Compound 4: no number reported, so the estimate cannot be set against anything.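

In this assay, among these compounds, compound 4 gives "not active" (no number reported), so no step from compound 3 to compound 4 can be read. No measured evidence bears on this result. The compounds shown leave open how 3,4-dichlorophenyl compares numerically with 2-chlorophenyl at this place.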